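Swapping methyl for methoxy in compound 3

The source may hold more compounds than are shown below. What is called first, only, known or untested is meant among the compounds shown, and "the series" means these compounds.

Measured so far in a functional assay on KB cells (Homo sapiens) for antiproliferative activity, read by sulforhodamine B assay, with a stated time of 3 days (a higher number here means that more compound is needed for the effect, a lower number that less compound is needed), are three compounds:
compound 1 `CCC1=C(O)c2c(oc(-c3ccc(OC)cc3)cc2=O)C(CC)(CC)C1=O` gives 17.7 uM
compound 2 `CCC1=C(O)c2c(oc(-c3ccccc3OC)cc2=O)C(CC)(CC)C1=O` gives 40.8 uM
compound 3 `CCC1=C(O)c2c(oc(-c3ccc(C)c(Cl)c3)cc2=O)C(CC)(CC)C1=O` gives 39 uM

Compound 3 stands level with compound 2, since a 1.0-fold lower number from compound 2 to compound 3 (0.02 log units; within the scatter) is a difference that says little. Compound 1 holds the lowest number, and a 2.2-fold higher number from compound 1 to compound 3 (0.34 log units; beyond the scatter) is a modest step. Compound 4 `CCC1=C(O)c2c(oc(-c3ccc(OC)c(Cl)c3)cc2=O)C(CC)(CC)C1=O` comes from compound 3 by one change (methoxy in place of methyl on an aromatic carbon) that gives methoxy in place of methyl on an aromatic carbon, so 3-chloro-4-methylphenyl becomes 3-chloro-4-methoxyphenyl.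

Within the data shown here, no measured step makes this swap alone. Among the measured compounds shown here, the closest is the one already named between compound 1 and compound 3, which also involves the chloro group and so cannot separate the two differences. The other, a 2.3-fold higher number from compound 1 to compound 2 (0.36 log units; beyond the scatter) in this assay, is similarly modest. Compound 4 keeps the methoxy of compound 1 and the chloro of compound 3, so a small move to a lower number is expected, perhaps none beyond the scatter. The estimated change is a 1.5-fold lower number from compound 3 to compound 4 (0.18 log units; within the scatter) and no larger shift is expected. In this assay the estimate for compound 4 is 26 uM, expected to fall between 12 uM and 50 uM in repeat measurements.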

Compound 4, concentration for half-maximal effect: 24.9 uM
Compound 4: the middle estimate sits 1.0-fold (0.02 log units) above what was measured; low and high end bracket the measured number.
By their numbers in this assay, from the lowest: compounds 1, 4, 3 and 2 (each within the scatter of the next, the first and the last beyond it).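

In this assay, methoxy in place of methyl, on the carbon ortho to a chloro group and para to a large group, is now seen alone, and the step stays small (a 1.6-fold lower number from compound 3 to compound 4 (0.19 log units; within the scatter)). Adding the chloro group in place of hydrogen to the 4-methoxyphenyl ring also stays within the scatter (a 1.4-fold higher number from compound 1 to compound 4 (0.15 log units; within the scatter)), as does replacing 2-methoxyphenyl with 3-chloro-4-methoxyphenyl (a 1.6-fold lower number from compound 2 to compound 4 (0.21 log units; within the scatter)), so neither single change on this ring shifts the number clearly here. No measurement shown explains these results.

The compounds shown leave open how an amine, a hydroxyl or a longer chain such as ethoxy would behave in place of the methoxy. They also leave open whether a fluoro or bromo group in place of the chloro would give a clearer step.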